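Amide variation on the shared core: binding at the 1F receptor

The compounds below may be only part of what the source reports. "The series", "measured", "known", "first", "only" and "open" are said of these compounds alone.

Measured compounds:
- compound 1, `CN1CCC(c2c[nH]c3cnc(NC(=O)c4ccc(F)cc4)cc23)CC1`: 13 nM
- compound 2, `CN1CCC(c2c[nH]c3ccc(NC(=O)C4CCCCC4)nc23)CC1`: 20 nM

In an assay for binding affinity to 5-hydroxytryptamine receptor 1F (Homo sapiens), read by radioligand binding (on this read-out lower numbers stand for stronger inhibition and higher numbers for weaker inhibition), compound 1 gives 13 nM and compound 2 gives 20 nM. Compound 2 has the higher of the two numbers, yet its gap to compound 1 lies within the scatter of repeated runs, so the two compounds are not distinguishable on this read-out. Among the measured compounds shown here, neither compound has a counterpart differing in one place, so no step between measured compounds is available; the two values show only that an aromatic amide and a saturated carbocyclic amide both reach comparable binding.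

Compound 3, `CN1CCC(c2c[nH]c3ccc(NC(=O)c4ccncc4)nc23)CC1`, is not yet measured. It differs from compound 2 by pyridin-4-yl in place of cyclohexyl on a carbonyl carbon. For the measured compounds named here, with no measured step of the same kind at hand, the expectation rests on the observation that compound 1, carrying an aromatic ring on the carbonyl carbon, gives 13 nM, a value within the scatter of compound 2. The step from compound 2 to compound 3 is therefore expected to stay within the scatter, a 1.3-fold higher number from compound 2 to compound 3 (0.10 log units; within the scatter), with no direction that can be claimed. Compound 3 is estimated at 25 nM, in the range 8 nM to 80 nM.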

Compound 3, inhibition constant: 8.4 nM
Compound 3: middle estimate off by 3.0-fold (0.47 log units), on the high side; the measured number falls inside the stated range.
By their numbers in this assay, from the lowest: compounds 3, 1 and 2 (each within the scatter of the next, the first and the last beyond it).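

In this assay, the exchange of cyclohexyl for pyridin-4-yl on a carbonyl carbon gives a 2.4-fold lower number from compound 2 to compound 3 (0.38 log units; beyond the scatter), a modest step but the first in this series that can be read beyond the scatter, so the group on this carbonyl does bear on the read-out. The two groups have the same count of heavy atoms, so the step does not come with a change in that count; the exchange instead replaces a non-aromatic ring of carbon only with an aromatic ring holding one nitrogen and one hydrogen-bond acceptor, and this single step cannot separate these differences from one another. No measurement at hand accounts for the step.

A plain phenyl group on the same carbonyl of the core of compound 2 would help to separate the contribution of the aromatic ring from that of its nitrogen, while pyridin-3-yl would test whether the position of that nitrogen matters. On these data alone, how far the trend extends beyond these rings also remains open, for example to an open chain such as n-butyl or to a saturated ring such as piperidin-4-yl.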